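A few compounds are considered here, and "the series" means these few. Any claim that something is new, unique, unknown or untested is made for them only; others in the source may bear on it.

Compound 1 `O=C(N/N=C/c1ccccc1)c1cnccn1` is the unsubstituted parent of a small set of hydrazones built on one shared core. It was tested in an ADME assay on J774 cells (Mus musculus) for cytotoxicity, read by MTT assay, with a stated time of 48 h, tested at 50 ug/mL (a lower number here means a stronger effect, a higher number a weaker effect of the compound at the concentration tested), and, in that assay, compound 1 gives 100%. Two analogues carry a halogen on the same benzene ring: compound 2 `O=C(N/N=C/c1ccc(Cl)cc1)c1cnccn1` gives 83% in this assay, and compound 3 `O=C(N/N=C/c1ccc(F)cc1)c1cnccn1` gives 78%. Compound 1 therefore holds the highest of the three numbers, with compound 2 nearest and compound 3 furthest from it.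

Compound 4 `O=C(N/N=C/c1cccc(Br)c1)c1cnccn1` is the next member. Compared with compound 1, the change is bromo in place of hydrogen on an aromatic carbon, and the entering group sits on an aromatic carbon of a six-membered aromatic ring of carbon only, meta to a large group.

For the measured compounds named here, two measured steps bear on this change. Putting chloro in place of hydrogen gave a number 17 percentage points lower from compound 1 to compound 2 (beyond the scatter), and putting fluoro in place of hydrogen gave a number 22 percentage points lower from compound 1 to compound 3 (beyond the scatter), while between the two halogenated compounds the step was a number 5 percentage points lower from compound 2 to compound 3 (within the scatter). Both halogen entries lowered the number by a modest amount, although neither sat where the bromo of compound 4 sits. On that basis compound 4 is expected to show a number 18 percentage points lower from compound 1 to compound 4 (beyond the scatter). The estimated value for compound 4 in this assay is 82%, with a range from 66% to 100%.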

Compound 4, a percentage reported as activity, at one concentration (the size of the read-out at that concentration, not a potency): 100%
Estimate against measurement, compound 4: 18 percentage points below; the measured number falls inside the stated range.
By their numbers in this assay, from the lowest: compounds 3 and 2 (each within the scatter of the next); then compounds 1 and 4 (each within the scatter of the next).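

In this assay, putting bromo in place of hydrogen on an aromatic carbon, meta to a large group, gave no change at the digits printed from compound 1 to compound 4 (within the scatter), so at this place the halogen leaves the read-out level with that of the parent. The two earlier halogen entries, which sit elsewhere on the ring, gave a number 17 percentage points lower from compound 1 to compound 2 (beyond the scatter) and a number 22 percentage points lower from compound 1 to compound 3 (beyond the scatter), so a halogen on this benzene ring does not lower the number in every case, and compound 4 is the one that goes against that trend. Nothing available accounts for this result, and with both the halogen and its place differing from the earlier entries, the data cannot say which of the two matters.

From the compounds shown here alone, what chloro or fluoro would give on this same carbon, and what bromo would give at the place held by the halogens of compounds 2 and 3, remains open. Going by these compounds, it is also open whether a larger or quite different group here, such as an amine, a carboxylic acid or a longer chain, would leave the number as level as bromo does.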